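Methyl at the Benzylic Carbon: From Compound 3 to Compound 4

The source may report more compounds than this note shows. Statements on the series, on what has been measured and on what is new or still open speak of the compounds shown alone.

Compound 3 `O=C1/C(=C\c2ccnc3ccccc23)c2ccccc2N1Cc1ccccc1` was tested in a functional assay on HL-60 cells (Homo sapiens) for cytotoxicity, read by MTT assay, with a stated time of 72 h, tested at 1 uM (on this read-out higher numbers stand for a weaker effect at the one concentration tested and lower numbers for a stronger effect), where compound 3 gives 85.2%. Among the three measured compounds, compound 3 stands second highest, and its number lies within the scatter of compound 1 `O=C1/C(=C\c2ccncc2)c2ccccc2N1Cc1ccccc1`, which in this assay gives 85.6%. Compound 2 `CC(c1ccccc1)N1C(=O)/C(=C\c2ccncc2)c2ccccc21` lies lowest of the three, with 49.2%. Compound 4 `CC(c1ccccc1)N1C(=O)/C(=C\c2ccnc3ccccc23)c2ccccc21` differs from compound 3 by methyl in place of hydrogen on a saturated chain carbon bound to an amide-type nitrogen in a ring and an aromatic carbon. For the measured compounds named here, the one measured step that bears on this change is a number 36.4 percentage points lower from compound 1 to compound 2 (beyond the scatter), the same exchange made on the other partner. A downward step of comparable size, beyond the scatter, is therefore expected here, namely a number 36.2 percentage points lower from compound 3 to compound 4 (beyond the scatter). On this basis compound 4 is estimated to give 49%, within a range from 32% to 68%.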

Compound 4, a percentage reported as activity, at one concentration (the size of the read-out at that concentration, not a potency): 72.6%
Compound 4: middle estimate off by 23.6 percentage points, on the low side; measured number outside the range, above it.
By their numbers in this assay, from the lowest: compound 2; then compound 4; then compounds 3 and 1 (each within the scatter of the next).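

Replacing benzyl with 1-phenylethyl again lowers the number, with a number 12.6 percentage points lower from compound 3 to compound 4 (beyond the scatter), so the direction of the step in this assay holds on both cores. The size of the step, however, does not carry over from one core to the other: the same change on two cores in this assay, a number 36.4 percentage points lower (beyond the scatter) from compound 1 to compound 2 and a number 12.6 percentage points lower (beyond the scatter) from compound 3 to compound 4, 23.8 percentage points apart, beyond the scatter of two such steps

Going by these compounds, whether a longer chain such as ethyl, or a hydroxyl group, on this saturated chain carbon would lower the number further remains open. The compounds shown also give no reason why the same change produces a smaller step on the core of compound 3.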